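From Difluorobenzyl to Butoxy on the Saturated Ring

This account rests on a few compounds, and the source may have more. Where it says the series, first, only, none or still open, it means among the compounds named here.

Of the compounds shown here, three with a shared core have been tested in a functional assay on CHO-K1 cells for antagonist activity at transient receptor potential cation channel subfamily V member 1 (Homo sapiens), read by FLIPR; a higher number here means a weaker inhibitor, a lower number a stronger inhibitor. Compound 1 `CC1CCC(Nc2nc(C(F)(F)F)ccc2CNC(=O)C(C)c2ccc(NS(C)(=O)=O)c(F)c2)CC1` gives 27.2 nM in this assay, and compound 2 `CC(C(=O)NCc1ccc(C(F)(F)F)nc1N(C)C)c1ccc(NS(C)(=O)=O)c(F)c1` gives 19.1 nM. For the measured compounds named here, the only single-point step among them, a 1.4-fold lower number from compound 1 to compound 2 (0.15 log units; within the scatter), concerns the group on an aromatic carbon of the core. Compound 3 `CC(C(=O)NCc1ccc(C(F)(F)F)nc1N1CCC(Cc2ccc(F)c(F)c2)CC1)c1ccc(NS(C)(=O)=O)c(F)c1` gives 0.2 nM in this assay, the lowest of the three numbers; compound 2 is nearest and compound 1 furthest, both beyond the scatter. Compound 4 `CCCCOC1CCN(c2nc(C(F)(F)F)ccc2CNC(=O)C(C)c2ccc(NS(C)(=O)=O)c(F)c2)CC1` differs from compound 3 by butoxy in place of 3,4-difluorobenzyl on a saturated ring carbon. Going by the values given here, no measured step touches this saturated ring carbon, and the one step that exists, from compound 1 to compound 2, lies elsewhere and within the scatter, so it offers no guide. The values of compound 2 and compound 3 show that the large group on the core accounts for a wide gap, which suggests that trimming it to butoxy may cost some potency. Compound 4 is therefore expected to give 2 nM in this assay, with a range from 0.4 nM to 10 nM. The step of a 10-fold higher number from compound 3 to compound 4 (1.00 log units; beyond the scatter) is estimated to be a rise beyond the scatter.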

Compound 4, inhibition constant: 3.5 nM
For compound 4 the middle estimate is 1.8-fold (0.24 log units) below the measured one; measured number inside the range.
By their numbers in this assay, from the lowest: compound 3; then compound 4; then compounds 2 and 1 (each within the scatter of the next).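

For the compounds shown here, replacing 3,4-difluorobenzyl with butoxy on the saturated ring carbon in this assay gives an 18-fold higher number from compound 3 to compound 4 (1.24 log units; beyond the scatter) and is the first measured change at this position, so the group there clearly matters. Yet the substituted saturated ring on the aromatic carbon still outperforms simpler groups with butoxy in place, giving a 5.5-fold lower number from compound 2 to compound 4 (0.74 log units; beyond the scatter) against dimethylamino and a 7.8-fold lower number from compound 1 to compound 4 (0.89 log units; beyond the scatter) against (4-methylcyclohexyl)amino. Nothing measured here explains why the group at this position alters the number.

The compounds shown do not separate the loss of the aromatic ring from the loss of the two fluorines or the arrival of the butoxy oxygen. A plain benzyl group or a pentyl chain on the same saturated ring carbon would help to distinguish these changes.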